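A few compounds are considered here, and "the series" means these few. Any claim that something is new, unique, unknown or untested is made for them only; others in the source may bear on it.

Compound 1 `O=C(CN1CCCC1)Nc1ccc(-c2nc3cc(C(F)(F)F)ccc3[nH]2)cc1` gives in an ADME assay on Vero cells (Chlorocebus sabaeus) for cytotoxicity (on this read-out higher numbers stand for lower toxicity in this test and lower numbers for higher toxicity in this test), only the limit > 100000 nM.
Compound 2 `O=C(CN1CCCCC1)Nc1ccc(-c2nc3ccccc3[nH]2)cc1` gives in this assay only the limit > 100000 nM.
Compound 3 `CCC(=O)Nc1ccc(-c2nc3ccccc3[nH]2)cc1` gives in this assay only the limit > 100000 nM.

Compound 3 therefore stands at the limit of this assay, and the two other values shown are limits as well, as the limit of > 100000 nM in this assay, at which 3 of the 3 values shown sit, records. Compound 4 `O=C(CN1CCCC1)Nc1ccc(-c2nc3ccccc3[nH]2)cc1` differs from compound 3 in one place: pyrrolidin-1-yl in place of methyl on a saturated chain carbon bound to a carbonyl carbon. Among the compounds with values here, the only measured step that touches this part of the molecule, a step that the two limits leave unreadable from compound 2 to compound 3, runs between two limits and its size cannot be read. On these numbers no step beyond the scatter is expected in this assay, and the step that the limit leaves unreadable from compound 3 to compound 4 is estimated as flat. Compound 4 is expected to give 150000 nM in this assay, within 100000 nM to 300000 nM, most likely again as a limit.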

Compound 4, half-maximal cytotoxic concentration: > 100000 nM
Compound 4: only a limit was reported (the forecaster's own chance of this, stated with the estimate: 90%); the middle value is on the limit's open side.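

Within the data shown here, compound 4 gives only a limit, as do compound 1, compound 2 and compound 3, so no step among them can be read: the limit of > 100000 nM in this assay, at which 4 of the 4 values shown sit. The compounds shown leave open whether any of these group changes alters the half-maximal cytotoxic concentration in this assay.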